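Methylating the phenol oxygen: from compound 2 to compound 4

A few compounds are considered here, and "the series" means these few. Any claim that something is new, unique, unknown or untested is made for them only; others in the source may bear on it.

Measured compounds and their values:
- compound 1, `O=C(Nc1cccc(-n2cc(-c3ccncc3)c(-c3cc(O)cc(Cl)c3)n2)c1)Nc1ccc(Cl)c(C(F)(F)F)c1`: -40%
- compound 2, `O=C(Nc1cccc(-n2cc(-c3ccncc3)c(-c3cc(O)cc(Cl)c3)n2)c1)Nc1ccc(Cl)c(Cl)c1`: -30%
- compound 3, `COc1cc(Cl)cc(-c2nn(-c3cccc(NC(=O)Nc4cc(C(F)(F)F)cc(C(F)(F)F)c4)c3)cc2-c2ccncc2)c1`: -8%

All three were tested in a functional assay on SR cells (Homo sapiens) for inhibition, read by sulforhodamine B assay, with a stated time of 48 h, tested at 100 uM; a lower number here means a stronger effect, a higher number a weaker effect of the compound at the concentration tested. Compound 2 gives -30%, the second highest of the three numbers; its nearest neighbour is compound 1 with -40%, which lies within the scatter, and its furthest is compound 3 with -8%, beyond the scatter.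

Compound 4, `COc1cc(Cl)cc(-c2nn(-c3cccc(NC(=O)Nc4ccc(Cl)c(Cl)c4)c3)cc2-c2ccncc2)c1`, has not yet been measured. It differs from compound 2 in one place: methyl in place of hydrogen on an oxygen on an aromatic ring.

Among the compounds with values here, the only measured step, a number 10 percentage points higher from compound 1 to compound 2 (within the scatter), concerns a different part of the molecule and so says nothing directly about this change. Compound 3 carries the methoxy group that compound 4 would carry, but it also differs from compound 2 in its urea aryl group, so only its two values can be compared, not attributed.

On this basis compound 4 is expected to land near -18%, between -40% and 5%, which would mean an expected step of a number 12 percentage points higher from compound 2 to compound 4 (beyond the scatter) in this assay, towards a weaker effect.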

Compound 4, a percentage reported as activity, at one concentration (the size of the read-out at that concentration, not a potency): -26%
Compound 4: middle estimate off by 8 percentage points, on the high side; the range from low to high includes it.
By their numbers in this assay, from the lowest: compounds 1, 2 and 4 (each within the scatter of the next, the first and the last beyond it); then compound 3.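

Putting a methyl group on the phenol oxygen gives a number 4 percentage points higher from compound 2 to compound 4 (within the scatter) in this assay, so hydroxy and methoxy cannot be told apart at this position in this pair. The hydrogen on that oxygen is therefore not needed for the effect seen at this single concentration, at least with the rest of compound 2 held fixed. Nothing measured here explains why this exchange is tolerated.

The compounds shown leave open whether the oxygen itself matters, which an amine or a plain methyl group at the same place would begin to test, and whether a longer chain such as ethoxy would also fit. They also leave open whether the same exchange would be tolerated with the trifluoromethyl-bearing aryl group of compound 1 in place.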